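Dropping the chlorophenyl arm from the weakest analogue

The source may report more compounds than this note shows. Statements on the series, on what has been measured and on what is new or still open speak of the compounds shown alone.

Measured compounds:
Compound 1 `C=C(Br)C(=O)Nc1ccc(/C=C2\SC(=O)N(Cc3cccc(Cl)c3)C2=O)cc1` — 3700 nM
Compound 2 `Nc1ccc(/C=C2\SC(=O)N(Cc3cccc(Cl)c3)C2=O)cc1` — 18000 nM
Compound 3 `C=C(Br)C(=O)Nc1cccc(/C=C2\SC(=O)N(Cc3ccccc3)C2=O)c1` — 510 nM

In a functional assay on CCRF-CEM cells (Homo sapiens) for cytotoxicity, read by cell counting, with a stated time of 3 days (a higher number here means a weaker inhibitor, a lower number a stronger inhibitor), compound 2 gives the highest number of the three, so it is the weakest inhibitor here; compound 1 lies closer, and compound 3 gives the lowest number. Among the compounds with values here, the one step that is measured, a 4.9-fold higher number from compound 1 to compound 2 (0.69 log units; beyond the scatter), comes from removing the (1-bromoethenyl)carbonyl group and sits on a different part of the molecule.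

Compound 4 `CCN1C(=O)S/C(=C\c2ccc(N)cc2)C1=O` keeps the free amine of compound 2 and changes the other end: methyl in place of 3-chlorophenyl on a saturated chain carbon bound to an amide-type nitrogen in a ring. Within the data shown here, no measured pair touches this position, so the step from compound 1 to compound 2 gives no direct guide, and compound 3 differs from the others in more than one place. Since compound 2 already sits at the weak end, a loss of the 3-chlorophenyl is expected to leave the number there or push it higher, with a 1.9-fold higher number from compound 2 to compound 4 (0.29 log units; within the scatter) as the expected shift. Compound 4 is expected to give 35000 nM, in the range 9000 nM to 120000 nM.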

Compound 4, half-maximal inhibitory concentration: 91000 nM
Beside the measured number, compound 4's estimate is 2.6-fold (0.41 log units) below it, and the stated range covers the measured number.
By their numbers in this assay, from the lowest: compound 3; then compound 1; then compound 2; then compound 4.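

In this assay, the 3-chlorophenyl group on a saturated chain carbon bound to an amide-type nitrogen in a ring proves to count: putting methyl in its place gives a 5.1-fold higher number from compound 2 to compound 4 (0.70 log units; beyond the scatter). Within the data shown here, this is the first measured step at this end of the molecule, and it shows that the number can still rise from an already weak compound, even with the (1-bromoethenyl)carbonyl group absent. Nothing shown here gives a reason for this shift.

Still open, on these data alone, is how a butyl chain or a cyclohexyl ring would read at this place, which would help separate the role of the aromatic ring from that of a larger group in general. As far as these compounds go, it is also open whether the same change would have a similar effect in a compound that keeps the (1-bromoethenyl)carbonyl group.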